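This account rests on a few compounds, and the source may have more. Where it says the series, first, only, none or still open, it means among the compounds named here.

Three close relatives share one core and differ only in the groups at its two ends. Compound 1 `CC(C)(C)c1cc(N)c2cc(NC(=O)/C=C/c3ccc(C(F)(F)F)cc3)ccc2n1` gives 0.3 nM in an assay on isolated protein for displacement of a labelled ligand from melanin-concentrating hormone receptor 1 (Homo sapiens); on this read-out higher numbers stand for weaker inhibition and lower numbers for stronger inhibition. Compound 3 `CCc1cc(N)c2cc(NC(=O)/C=C/c3ccc(C(F)(F)F)cc3)ccc2n1` gives 1.2 nM, and compound 2 `CCCc1cc(N)c2cc(NC(=O)/C=C/c3ccc(CC)cc3)ccc2n1` gives 1.4 nM. Compound 2 thus has the highest number of the three: its gap to compound 3 is within the scatter, while its gap to compound 1 is beyond it. Going by the values given here, the one single-point step known here, a 4.0-fold higher number from compound 1 to compound 3 (0.60 log units; beyond the scatter), concerns the group on the aromatic carbon of the core, not the ring at the far end of the chain.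

Compound 4 `CCCc1cc(N)c2cc(NC(=O)/C=C/c3ccc(Cl)cc3Cl)ccc2n1` is the untested member. Relative to compound 2 the change is 2,4-dichlorophenyl in place of 4-ethylphenyl on a double-bonded chain carbon bound to a double-bonded chain carbon. Among the compounds with values here, no measured step touches this end of the molecule, so nothing directly predicts the effect; the step of a 1.4-fold lower number from compound 2 to compound 4 (0.15 log units; within the scatter) is therefore an expectation without a precedent, and compound 4 is estimated at 1 nM, within 0.3 nM to 3.5 nM.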

Compound 4, half-maximal inhibitory concentration: 6.6 nM
Compound 4: middle estimate off by 6.6-fold (0.82 log units), on the low side; the measured number lies above the stated range.
By their numbers in this assay, from the lowest: compound 1; then compounds 3 and 2 (each within the scatter of the next); then compound 4.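

Going by these compounds alone, compound 4 gives the first direct look at the ring at the far end of the chain: 2,4-dichlorophenyl in place of 4-ethylphenyl produces a 4.7-fold higher number from compound 2 to compound 4 (0.67 log units; beyond the scatter) in this assay. This shows that the number responds to this end of the molecule, and not only to the group on the aromatic carbon of the core. The two groups have the same heavy-atom count, the same kind of ring, the same donor and acceptor counts and no net charge, so these counts do not account for the difference, and no available evidence explains it.

A phenyl ring carrying a single chlorine could help show whether one chlorine or both go with the change. On these data alone, how an amine or a carboxylic acid on this ring would fare also remains open.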